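Compound 4: a bromophenyl replaces the fluorophenyl

The compounds below may be only part of what the source reports. "The series", "measured", "known", "first", "only" and "open" are said of these compounds alone.

Measured so far, in a functional assay on HT-29 cells (Homo sapiens) for cytotoxicity, read by MTT assay, with a stated time of 72 h; a lower number here means a stronger inhibitor, a higher number a weaker inhibitor:
compound 1 `COc1cc2c(Oc3ccc(NC(=O)c4nn(-c5ccccc5F)c(=O)c5ccccc45)cc3F)ccnc2cc1OCCCN1CCCC1` gives 400 nM
compound 2 `COc1cc2c(Oc3ccc(NC(=O)c4nn(-c5ccc(F)cc5)c(=O)c5ccccc45)cc3F)ccnc2cc1OCCCN1CCN(C)CC1` gives 320 nM
compound 3 `COc1cc2c(Oc3ccc(NC(=O)c4nn(-c5ccc(F)cc5)c(=O)c5ccccc45)cc3F)ccnc2cc1OCCCN1CCC(C)CC1` gives 330 nM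

Among these three numbers compound 3 stands second highest. Its nearest neighbour is compound 2, and the gap between them is within the usual scatter; its furthest is compound 1, and that gap too lies within the scatter. For the measured compounds named here, the one single-point step in the set, a 1.0-fold higher number from compound 2 to compound 3 (0.01 log units; within the scatter), changes only the end of the chain and leaves the number essentially unmoved.

Compound 4 `COc1cc2c(Oc3ccc(NC(=O)c4nn(-c5ccccc5Br)c(=O)c5ccccc45)cc3F)ccnc2cc1OCCCN1CCC(C)CC1` differs from compound 3 in one place: 2-bromophenyl in place of 4-fluorophenyl on an aromatic nitrogen. Going by the values given here, no measured step alters this group alone, so nothing directly bears on it. Compound 1 differs from compound 2 in two places at once, and all that can be said is that its value sits close to those of compound 2 and compound 3. On that basis the expected step from compound 3 to compound 4 in this assay is small, a 1.1-fold higher number from compound 3 to compound 4 (0.03 log units; within the scatter), with no clear direction. Compound 4 is therefore estimated at 350 nM, most likely between 150 nM and 800 nM.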

Compound 4, half-maximal inhibitory concentration: 950 nM
Beside the measured number, compound 4's estimate is 2.7-fold (0.43 log units) below it, and the stated range ends below it.
By their numbers in this assay, from the lowest: compounds 2, 3 and 1 (each within the scatter of the next); then compound 4.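

In this assay, for the compounds shown here, the group on the aromatic nitrogen is the first change in this set to move the number beyond the scatter: 2-bromophenyl in place of 4-fluorophenyl gives a 2.9-fold higher number from compound 3 to compound 4 (0.46 log units; beyond the scatter), a modest loss, whereas the change at the end of the chain gave a 1.0-fold higher number from compound 2 to compound 3 (0.01 log units; within the scatter). The counts computed for the two groups do not separate them, since both have the same number of heavy atoms, one six-membered carbon ring, no hydrogen-bond donors or acceptors and no net charge. No measurement on hand explains the loss.

This single step swaps the halogen and moves its place together, so the compounds shown cannot tell which of the two matters. A plain phenyl or a chlorophenyl on the same nitrogen, with the 4-methylpiperidin-1-yl chain end kept, would help to pull these apart.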